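A few compounds are considered here, and "the series" means these few. Any claim that something is new, unique, unknown or untested is made for them only; others in the source may bear on it.

Measured in an ADME assay on BHK-21 cells (Mesocricetus auratus) for cytotoxicity, read by MTT assay; on this read-out higher numbers stand for lower toxicity in this test and lower numbers for higher toxicity in this test:
- Compound 1 `CC(=O)c1ccc2[nH]c(-c3ccccc3)nc2c1`: > 100000 nM (a limit)
- Compound 2 `COc1ccc(-c2nc3cc(C(C)=O)ccc3[nH]2)c(OC)c1OC`: > 100000 nM (a limit)
- Compound 3 `CC(=O)c1ccc2c(c1)nc(-c1ccccc1)n2C1CCCCC1`: 100000 nM

Going by the values given here, compound 3 gives the only number that is not a limit, 100000 nM. The other two results stand at the limit of > 100000 nM in this assay, at which 2 of the 3 values shown sit.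

Compound 4 `COc1ccc(-c2nc3cc(C(C)=O)ccc3n2C2CCCCC2)cc1` has methoxy in place of hydrogen on an aromatic carbon of compound 3: methoxy in place of hydrogen on an aromatic carbon.

Among the compounds with values here, no measured step covers this change. Within the data shown here, the one measured step, a number no higher from compound 1 to compound 3 (the limit leaves the size open), is cyclohexyl in place of hydrogen on an aromatic nitrogen, and its size cannot be read. Compound 2 carries methoxy groups, and its > 100000 nM is a limit.

With compound 3 at 100000 nM, no step beyond the scatter is expected in this assay. The estimated change is a 1.3-fold lower number from compound 3 to compound 4 (0.10 log units; within the scatter). Compound 4 is expected at 80000 nM, with an estimated range of 30000 nM to 150000 nM.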

Compound 4, half-maximal cytotoxic concentration: > 100000 nM
Compound 4 gave a limit, no number (the forecaster's own chance of this, stated with the estimate: 45%); middle value at least 1.2-fold (0.09 log units) away from the limit.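

In this assay compound 4 gives > 100000 nM, which is a limit and not a number. Methoxy in place of hydrogen, para to a large group, gives a number no lower from compound 3 to compound 4 (the limit leaves the size open), a step whose size cannot be read; it shows only that this change, on a compound carrying cyclohexyl, brought no lower number, which compound 2, without cyclohexyl, could not show. Most results now stand at one limit: the limit of > 100000 nM in this assay, at which 3 of the 4 values shown sit.

From the compounds shown here alone, whether an amine or a carboxylic acid at this place would bring a lower number stays open. So does the real size of the values behind the limits.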